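A few compounds are considered here, and "the series" means these few. Any claim that something is new, unique, unknown or untested is made for them only; others in the source may bear on it.

Of the compounds shown here, three have been measured in a functional assay on SK-OV-3 cells (Homo sapiens) for inhibition, read by sulforhodamine B assay, with a stated time of 48 h, tested at 10 uM; a higher number here means more inhibition of growth at the concentration tested, a lower number less inhibition of growth. Compound 1 `C/C(=N\O)c1ccc(NC(=O)Cn2nc(-c3ccc(Cl)cc3)nc2N)cc1` gives 27.4% in this assay. Compound 2 `c1ccc(-c2nc3sc(-c4ccccc4)cn3n2)cc1` gives 5% in this assay, and compound 3 `COc1ccc(-c2nc3sc(-c4ccc(Cl)cc4)cn3n2)cc1` gives 50.6% in this assay. Compound 3 thus stands highest of the three: compound 1 is nearest, lower by a margin beyond the usual scatter, and compound 2 is furthest, lower by a margin that also exceeds the scatter. No two of these compounds differ in only one place, so no single structural step has been isolated among them.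

Compound 4 `Clc1ccc(-c2cn3nc(-c4ccccc4)nc3s2)cc1` has not yet been measured in this assay. It differs from compound 3 in one place: hydrogen in place of methoxy on an aromatic carbon. Compound 2, which carries no methoxy, gives a far lower number than compound 3, though compound 2 differs from compound 3 in another place as well, so this is a hint and not a measured step. In this assay a downward step of about a number 25.6 percentage points lower from compound 3 to compound 4 (beyond the scatter) is expected. Compound 4 is accordingly estimated at 25%, within a range from 5% to 45%.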

Compound 4, percent growth inhibition at one concentration: 64%
The estimate for compound 4 lay 39 percentage points below the measured number; measured number outside the range, above it.
By their numbers in this assay, from the lowest: compound 2; then compound 1; then compound 3; then compound 4.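

In this assay, among these compounds, the methoxy proves not to be needed for growth inhibition on this core: hydrogen in its place gives a number 13.4 percentage points higher from compound 3 to compound 4 (beyond the scatter), the opposite direction to what the earlier compounds hinted. The chloro now has a clean single-place comparison as well, and chloro in place of hydrogen on an aromatic carbon gives a number 59 percentage points higher from compound 2 to compound 4 (beyond the scatter), a large step. Nothing measured here explains why either change moves the number as it does.

On these data alone, at the position para to a large group, only methoxy and hydrogen can be compared, so the effect of an amine, a carboxylic acid or a longer chain such as ethoxy remains open. Also open, as far as these compounds go, is whether chloro gives a step of similar size when methoxy is present on the other ring.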